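The source may report more compounds than this note shows. Statements on the series, on what has been measured and on what is new or still open speak of the compounds shown alone.

Compound 3 `CC1CCCC(C)N1CCCCCN1C(=O)C(c2cccc(C(=N)NO)c2)Oc2ccccc21` stands highest of the three numbers measured in an assay on isolated protein for inhibition of serine protease 1 (Homo sapiens), tested at 100 uM (a higher number here means more inhibition at the concentration tested (going by the name of the read-out), a lower number less inhibition), where compound 3 gives 21%. Compound 1 `COc1ccc(C2Oc3ccccc3N(CCCCCN3C(C)CCCC3C)C2=O)cc1` gives 2.3% in this assay, and compound 2 `COc1ccc(C2Oc3ccccc3N(CCCCCN3C(C)CCCC3C)C2=O)cc1OC` gives 0%. The step of a number 18.7 percentage points higher from compound 1 to compound 3 (beyond the scatter) and the step of a number 21 percentage points higher from compound 2 to compound 3 (beyond the scatter) both lie beyond the scatter, whereas the step of a number 2.3 percentage points lower from compound 1 to compound 2 (within the scatter) does not.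

Compound 4 `CC1CCCC(C)N1CCCCCN1C(=O)C(c2cccc(C(=N)NN3CCOCC3)c2)Oc2ccccc21` differs from compound 3 in one place: morpholin-4-yl in place of hydroxy on an amine nitrogen. The group that leaves is hydroxy, the group that enters is morpholin-4-yl, and the place is an amine nitrogen whose other neighbour is a carbon with a double bond to nitrogen.

For the measured compounds named here, none of the measured steps alters this part of compound 3; the two steps that reach compound 3 exchange the whole aromatic group on the saturated ring carbon, and so they say only that the group carrying the amine nitrogen raised the read-out in this assay. What happens when its hydroxy is exchanged for morpholin-4-yl is not covered by any measured pair. Compound 4 is therefore expected to stay near compound 3, with a step of a number 4 percentage points lower from compound 3 to compound 4 (within the scatter) that may fall within the scatter. The estimate for compound 4 in this assay is 17%, within a range from 2% to 38%.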

Compound 4, a percentage reported as inhibition, at one concentration (the size of the read-out at that concentration, not a potency): 58%
Beside the measured number, compound 4's estimate is 41 percentage points below it; the whole stated range lies below it.
By their numbers in this assay, from the lowest: compounds 2 and 1 (each within the scatter of the next); then compound 3; then compound 4.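

For the compounds shown here, the exchange of hydroxy for morpholin-4-yl on the amine nitrogen gives a number 37 percentage points higher from compound 3 to compound 4 (beyond the scatter) in this assay, a large step, whereas the earlier steps that exchanged the whole aromatic group on the saturated ring carbon were modest. This shows that the read-out is sensitive to the group on this amine nitrogen, whose other neighbour is a carbon with a double bond to nitrogen, and that in this pair the hydroxy is not needed for inhibition, since the entering group has a six-membered ring and no hydrogen-bond donor. Nothing available here gives a reason for the rise.

This single pair leaves open whether the gain belongs to the six-membered ring as a whole or to its oxygen, a question that piperidin-1-yl on the same nitrogen could help to settle, with an open-chain dimethylamino group showing whether a ring is needed at all. It also leaves open the potency of compound 4, since the read-out describes inhibition at only one concentration.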